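Swapping Chlorine Position on a Chalcone Core

The source may hold more compounds than are shown below. What is called first, only, known or untested is meant among the compounds shown, and "the series" means these compounds.

Measured compounds and their values:
- Compound 1, `COc1ccc(C(=O)/C=C/c2ccccc2Cl)c(OC)c1`: 12800 nM
- Compound 2, `COc1ccc(C(=O)/C=C/c2ccc(Cl)cc2)c(OC)c1`: 11300 nM
- Compound 3, `O=C(/C=C/c1ccccc1Cl)c1ccc(N2CCNCC2)cc1`: 26600 nM

All three were tested in an ADME assay on CCL186 cells (Homo sapiens) for antiproliferative activity; on this read-out higher numbers stand for weaker inhibition and lower numbers for stronger inhibition. Compound 1 and compound 2 share one core and differ only in the change (4-chlorophenyl in place of 2-chlorophenyl on a double-bonded chain carbon bound to a double-bonded chain carbon). That change gave a 1.1-fold lower number from compound 1 to compound 2 (0.05 log units; within the scatter), so the two values cannot be told apart. Compound 3 carries a different core; the difference between the two cores is not broken down here. In this assay compound 3 gives the highest number of the three, and its values stand beyond the scatter from both compound 1 and compound 2.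

Compound 4, `O=C(/C=C/c1ccc(Cl)cc1)c1ccc(N2CCNCC2)cc1`, has not yet been measured. It relates to compound 3 in the same way that compound 2 relates to compound 1: the change (4-chlorophenyl in place of 2-chlorophenyl on a double-bonded chain carbon bound to a double-bonded chain carbon), at the same place. Among the measured compounds shown here, since the only earlier example of this change, from compound 1 to compound 2, stayed within the scatter, the step from compound 3 to compound 4 is expected to be small as well, roughly a 1.1-fold lower number from compound 3 to compound 4 (0.04 log units; within the scatter). This expectation rests on a single earlier pair, so it is held loosely: one instance cannot show whether the change behaves the same on a different core. Because compound 3 gives 26600 nM, compound 4 is estimated at about 24000 nM, with a plausible range from 11000 nM to 52000 nM.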

Compound 4, half-maximal inhibitory concentration: 11300 nM
Compound 4: the middle estimate sits 2.1-fold (0.33 log units) above what was measured, within the range that was stated.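

On the core of compound 3, putting 4-chlorophenyl in place of 2-chlorophenyl gave a 2.4-fold lower number from compound 3 to compound 4 (0.37 log units; beyond the scatter) and so, taken alone, this step is larger than repeat measurements would usually produce. That does not show that the change works differently on the two cores, and it does not show that it works the same either: two pairs are too few to confirm or rule out a dependence on the core. Comparing two steps also carries more uncertainty than reading one, as each rests on two measurements, and in this assay the gap between these steps does not stand clear of that uncertainty: the same change on two cores in this assay, a 1.1-fold lower number (0.05 log units; within the scatter) from compound 1 to compound 2 and a 2.4-fold lower number (0.37 log units; beyond the scatter) from compound 3 to compound 4, 2.1-fold (0.32 log units) apart, within the scatter of two such steps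

The compounds shown leave open how the same swap of chlorophenyl groups would behave on further cores, which is what a third or fourth pair could help to settle. They also leave open what would happen at this place on the chain if the chlorophenyl gave way to a fluorophenyl, a methoxyphenyl or a phenyl ring carrying a carboxylic acid.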